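This account rests on a few compounds, and the source may have more. Where it says the series, first, only, none or still open, it means among the compounds named here.

Compound 1 `Cc1cc(C)c(CN2CCc3c(Cl)cc([C@@H](CO)[C@@H]4CCOC4)c(Cl)c3C2=O)c(=O)[nH]1`: 3 10^-6 cm/s
Compound 2 `COc1cc(C)[nH]c(=O)c1CN1CCc2c(Cl)cc(C(OC)C3(C)COC3)c(Cl)c2C1=O`: 5.7 10^-6 cm/s; 4.8 10^-6 cm/s (2 entries)
Compound 3 `COC(c1cc(Cl)c2c(c1Cl)C(=O)N(Cc1c(C)cc(C)[nH]c1=O)CC2)C1CCN(C(=O)CO)CC1`: 7.3 10^-6 cm/s; 7.1 10^-6 cm/s (2 entries)

All three share a core and were tested in an ADME assay on MDCK cells (Canis lupus familiaris) for permeability, read by LC-MS, with a stated time of 90 min, tested at 2 uM; on this read-out higher numbers stand for higher permeability and lower numbers for lower permeability. Compound 1 gives 3 10^-6 cm/s, the smaller number of the set; compound 3 gives 7.3 10^-6 cm/s; 7.1 10^-6 cm/s (2 entries), clearly apart from it, while compound 2 gives 5.7 10^-6 cm/s; 4.8 10^-6 cm/s (2 entries), not separated from compound 1 beyond the usual scatter. The repeats of compound 2 (the several entries of compound 2 in this assay, 5.7 10^-6 cm/s; 4.8 10^-6 cm/s (2 entries)) and of compound 3 (the several entries of compound 3 in this assay, 7.3 10^-6 cm/s; 7.1 10^-6 cm/s (2 entries)) agree closely, so the numbers are steady. Compound 4 `Cc1cc(C)c(CN2CCc3c(Cl)cc([C@H](CO)[C@H]4CCCO4)c(Cl)c3C2=O)c(=O)[nH]1` has not been measured. It differs from compound 1 by a group of 8 heavy atoms (6 carbon, 2 oxygen; one five-membered non-aromatic ring with 1 hetero atom) in place of a group of 8 heavy atoms (6 carbon, 2 oxygen; one five-membered non-aromatic ring with 1 hetero atom), on an aromatic carbon. Going by the values given here, no measured step of this kind is at hand, so the expected step is a 1.2-fold higher number from compound 1 to compound 4 (0.07 log units; within the scatter), no larger than the scatter. Compound 4 is therefore estimated at 3.5 10^-6 cm/s, within 1.5 10^-6 cm/s to 8 10^-6 cm/s.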

Compound 4, apparent permeability: 4.1 10^-6 cm/s
For compound 4 the middle estimate is 1.2-fold (0.07 log units) below the measured one, and the stated range covers the measured number.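

In this assay the exchange of one side group for another made of the same atoms, joined differently, gives a 1.4-fold higher number from compound 1 to compound 4 (0.14 log units; within the scatter) and so leaves the two compounds unseparated. At this aromatic carbon, ortho to a chloro group, the read-out therefore tolerates this rearrangement of the five-membered non-aromatic ring and its two defined stereocentres. Nothing measured here offers a reason for the size of this step.

Still open, as far as these compounds go, is whether an amine or a carboxylic acid at this same carbon would shift the number. The same question stands for a longer chain there.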